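A Fluorine on the Fused Ring of Compound 1

The source may hold more compounds than are shown below. What is called first, only, known or untested is meant among the compounds shown, and "the series" means these compounds.

Measured compounds:
compound 1 `O=C1c2ccccc2C(=O)N1c1nc(-c2ccc(Cl)cc2)cs1` gives 44900 nM
compound 2 `Cc1ccc(-c2csc(N3C(=O)c4ccccc4C3=O)n2)cc1` gives 38400 nM

These two compounds were tested in a functional assay on PC-3 cells (Homo sapiens) for antiproliferative activity, read by MTT assay, with a stated time of 48 h; on this read-out lower numbers stand for stronger inhibition and higher numbers for weaker inhibition. Compound 1 gives the highest of the two numbers; its nearest neighbour is compound 2, and the step of a 1.2-fold lower number from compound 1 to compound 2 (0.07 log units; within the scatter) is within the scatter, so the two values cannot be told apart.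

The compound to be estimated is compound 3 `O=C1c2ccc(F)cc2C(=O)N1c1nc(-c2ccc(Cl)cc2)cs1`. It differs from compound 1 in one place: fluoro in place of hydrogen on an aromatic carbon. For the measured compounds named here, the only measured step, the one from compound 1 to compound 2, concerns the methyl group in place of chloro on the other ring, not the six-membered aromatic ring of carbon only that is part of the fused system, so no measured step bears directly on this change. With nothing to suggest otherwise, the expectation is for no step beyond the scatter in this assay; the expected step is a 1.1-fold lower number from compound 1 to compound 3 (0.03 log units; within the scatter).

Compound 3 is therefore estimated at 42000 nM, with a range from 15000 nM to 110000 nM.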

Compound 3, half-maximal inhibitory concentration: 38000 nM
Beside the measured number, compound 3's estimate is 1.1-fold (0.04 log units) above it; the measured number falls inside the stated range.
By their numbers in this assay, from the lowest: compounds 3, 2 and 1 (each within the scatter of the next).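

In this assay, adding a fluoro group in place of hydrogen on the fused ring gives a 1.2-fold lower number from compound 1 to compound 3 (0.07 log units; within the scatter), which cannot be told apart from the difference expected between repeated measurements. For the compounds shown here, this is the first measured change on that ring, as the earlier step between compound 1 and compound 2 concerned only the other aromatic ring, so it shows that this carbon can carry one added fluorine atom without a readable shift in the antiproliferative number. Nothing measured here explains why the number does not shift beyond the scatter, and a step this small gives no basis for ranking the hydrogen and fluoro versions of the compound.

As far as these compounds go, it remains open whether a different group on this same carbon, such as an amine, a carboxylic acid or a longer chain, would produce a step beyond the scatter. From the compounds shown here alone, it is also open whether fluoro would give a similarly small step on another carbon of the fused ring, or on this carbon with methyl in place of chloro on the other ring, as in compound 2.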